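The compounds below may be only part of what the source reports. "The series", "measured", "known", "first", "only" and "open" are said of these compounds alone.

Working notes on the series.

Among the compounds with values here, compound 2 `c1csc(-c2noc(-c3ccc(C4=NCCN4)cc3)n2)c1` shows the highest number of the two so far measured in an assay for inhibition of Amine oxidase [flavin-containing] B (Homo sapiens), read by fluorescence and spectrophotometry, using microsomes, with stated times of 30 min and 20 min; on this read-out lower numbers stand for stronger inhibition and higher numbers for weaker inhibition: compound 2 gives 890 nM. The nearest number belongs to compound 1 `Clc1cccc(-c2nc(-c3cccc(C4=NCCN4)c3)no2)c1`, which in this assay gives 30 nM; the gap between compound 2 and compound 1 lies well beyond the scatter, and since the two differ in more than one place, their values say only that much.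

Compound 3 `COc1cccc(-c2noc(-c3ccc(C4=NCCN4)cc3)n2)c1` shares the core of compound 2 and changes one group: 3-methoxyphenyl in place of thiophen-2-yl on an aromatic carbon. Within the data shown here, no measured pair isolates this change, so no step can be drawn from the data. Given that compound 1, the only compound carrying a six-membered aromatic ring of carbon only on the core, gives 30 nM, a moderate move toward lower numbers is expected from compound 2 to compound 3, about a 3.0-fold lower number from compound 2 to compound 3 (0.47 log units; beyond the scatter), although the size is uncertain. In this assay compound 3 is expected to give roughly 300 nM, with a range from 80 nM to 1500 nM.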

Compound 3, half-maximal inhibitory concentration: 216 nM
Beside the measured number, compound 3's estimate is 1.4-fold (0.14 log units) above it; low and high end bracket the measured number.
By their numbers in this assay, from the lowest: compound 1; then compound 3; then compound 2.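

Within the data shown here, on the aromatic carbon between two ring nitrogen atoms, the first single-change comparison in this assay shows 3-methoxyphenyl in place of thiophen-2-yl giving a 4.1-fold lower number from compound 2 to compound 3 (0.61 log units; beyond the scatter) as the step, so the group at this position affects the read-out. The step swaps a five-membered aromatic ring with 1 hetero atom for a six-membered aromatic ring of carbon only, while the hydrogen-bond acceptor count of the two groups stays the same. Nothing at hand gives a reason for this step.

As far as these compounds go, whether the step belongs to the ring or to the methoxy group stays open, and plain phenyl at this place, or phenyl carrying an amine or a carboxylic acid, would help separate the two. Among these compounds, compound 1 differs from compound 2 and compound 3 in more than one place, so no step to it can be read.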